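The compounds below may be only part of what the source reports. "The series", "measured", "known", "first", "only" and "open" are said of these compounds alone.

Measured so far:
compound 1 `CCN(C/C=C/C#CC(C)(C)C)Cc1cccc(OC[Si](C)(C)c2ccc(Br)cc2)c1`: 210 nM
compound 2 `CCN(C/C=C/C#CC(C)(C)C)Cc1cccc(OC[Si](C)(C)c2ccc(OC)cc2)c1`: 870 nM
compound 3 `CCN(C/C=C/C#CC(C)(C)C)Cc1cccc(OC[Si](C)(C)c2ccc(C(=O)C(F)(F)F)cc2)c1`: 5000 nM

In a functional assay on liver (Sus scrofa) for inhibition of squalene monooxygenase (Homo sapiens), using microsomes (on this read-out higher numbers stand for weaker inhibition and lower numbers for stronger inhibition), compound 3 gives the highest number of the three, the weakest inhibition: its nearest neighbour is compound 2 (a 5.7-fold higher number from compound 2 to compound 3 (0.76 log units; beyond the scatter)), the furthest compound 1 (a 24-fold higher number from compound 1 to compound 3 (1.38 log units; beyond the scatter)). Compound 4 `CCN(C/C=C/C#CC(C)(C)C)Cc1cccc(OC[Si](C)(C)Cc2ccccc2)c1` alters the group on the silicon: benzyl in place of 4-((trifluoromethyl)carbonyl)phenyl on a silicon. Both measured steps bear on this, since each changes only what sits on that aromatic ring; one was large, one modest, and both point to the trifluoromethylcarbonyl-bearing ring as the least favourable. Removing it for benzyl is therefore expected to lower the number in this assay by a modest to large step, an 8.3-fold lower number from compound 3 to compound 4 (0.92 log units; beyond the scatter). Compound 4 is expected to give 600 nM in this assay, within 150 nM to 2500 nM.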

Compound 4, half-maximal inhibitory concentration: 130 nM
The estimate for compound 4 lay 4.6-fold (0.66 log units) above the measured number; the measured number lies below the stated range.
By their numbers in this assay, from the lowest: compounds 4 and 1 (each within the scatter of the next); then compound 2; then compound 3.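

In this assay the position on the silicon accepts a change of the group itself, not only of what sits on the aromatic ring: a 38-fold lower number from compound 3 to compound 4 (1.59 log units; beyond the scatter) and a 6.7-fold lower number from compound 2 to compound 4 (0.83 log units; beyond the scatter) are both beyond the scatter. Benzyl and 4-bromophenyl cannot be ordered, since a 1.6-fold lower number from compound 1 to compound 4 (0.21 log units; within the scatter) lies within it. No measurement here explains why benzyl is tolerated.

Still open, from the compounds shown here alone, is how unsubstituted phenyl or a longer 2-phenylethyl chain on the silicon would read in this assay. Also open, going by these compounds, is whether a bromo substituent on the benzyl ring would lower the number further.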